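From Thiophene Back to a Substituted Phenyl

The compounds below may be only part of what the source reports. "The series", "measured", "known", "first", "only" and "open" are said of these compounds alone.

Of the compounds shown here, two of the shared core have been measured so far. Compound 1, `c1ccc(-c2cn3ccnc3c(-c3ccc4ncn(C5CCCCC5)c4c3)n2)cc1`, bears a phenyl group; in a functional assay on RXF 393 cells (Homo sapiens) for inhibition, read by sulforhodamine B assay, with a stated time of 48 h, tested at 10 uM (a lower number here means less inhibition, a higher number more inhibition at the concentration tested (going by the name of the read-out)), compound 1 gives 45%. Compound 2, `c1cn2cc(-c3ccsc3)nc(-c3ccc4ncn(C5CCCCC5)c4c3)c2n1`, carries a thiophen-3-yl in its place, and in this assay compound 2 gives 8.63%. Among the measured compounds shown here, the single measured step is a number 36.4 percentage points lower from compound 1 to compound 2 (beyond the scatter). Compound 2 thus stands lowest of the two numbers, with compound 1 the nearest and higher by a margin beyond the scatter.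

Compound 3, `COc1ccccc1-c1cn2ccnc2c(-c2ccc3ncn(C4CCCCC4)c3c2)n1`, is not yet measured. It differs from compound 2 as follows: 2-methoxyphenyl in place of thiophen-3-yl on an aromatic carbon. For the measured compounds named here, the one measured step bears on this change, as it exchanged a phenyl for the thiophen-3-yl that now leaves again, and that step was large. The entering 2-methoxyphenyl, like the phenyl of compound 1 with its 45%, has a six-membered ring of carbon only. For compound 3 the expected step in this assay is a number 26.4 percentage points higher from compound 2 to compound 3 (beyond the scatter), upward and beyond the scatter. Compound 3 is therefore estimated at 35%, with a range from 10% to 60%. Going by the values given here, the 2-methoxyphenyl itself has no measured precedent here, so the estimate leans on compound 1 alone.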

Compound 3, a percentage reported as inhibition, at one concentration (the size of the read-out at that concentration, not a potency): 0.95%
Compound 3: middle estimate off by 34.1 percentage points, on the high side; the measured number lies below the stated range.
By their numbers in this assay, from the lowest: compounds 3 and 2 (each within the scatter of the next); then compound 1.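

In this assay, a six-membered aromatic ring of carbon only does not by itself secure the higher number of compound 1: methoxy in place of hydrogen on that phenyl gives a number 44.1 percentage points lower from compound 1 to compound 3 (beyond the scatter), a large step from one small change. Replacing thiophen-3-yl with 2-methoxyphenyl gives a number 7.7 percentage points lower from compound 2 to compound 3 (within the scatter), so at this aromatic carbon, two atoms from the ring nitrogen, these two groups are not told apart, and of the three compounds only the unsubstituted phenyl of compound 1 stands clear of the others. Nothing shown explains why one methoxy has so large an effect at this place.

The compounds shown leave open whether the loss belongs to the methoxy itself or would follow any group on this phenyl, which a hydroxy group, a chlorine atom or an amine on the ring could help to settle. They also leave open whether the same methoxy elsewhere on the phenyl would give a similar number, and whether a pyridyl ring in this place would stand with compound 1 or with the others.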